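Dichloro Purine Analogue: Expected Cytotoxicity on Myeloma Cells

The source may report more compounds than this note shows. Statements on the series, on what has been measured and on what is new or still open speak of the compounds shown alone.

Measured so far:
- compound 1, `ClCc1ccccc1Cn1cnc2c(Cl)nc(Cl)nc21` — in a functional assay on RPMI-8226 cells (Homo sapiens) for cytotoxicity, read by sulforhodamine B assay, with a stated time of 48 h (a lower number here means that less compound is tolerated, a higher number that more compound is tolerated), compound 1 gives "not determined" (no result reported)
- compound 2, `ClCc1ccccc1Cn1cnc2c(Cl)ncnc21` — in this assay compound 2 reaches only the limit > 100000 nM
- compound 3, `ClCc1cccc(Cn2cnc3c(Cl)ncnc32)c1` — in this assay compound 3 gives 87100 nM

Within the data shown here, compound 3 is the only compound for which a number is available. For compound 2 the result is a limit of the assay rather than a number, so the value is not known exactly. For compound 1 nothing was reported. Among the shown values, one sits at the limit (the limit of > 100000 nM in this assay, at which 1 of the 3 values shown sits), which shows how close compound 3 itself lies to the edge of what the assay can resolve.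

Compound 4, `ClCc1cccc(Cn2cnc3c(Cl)nc(Cl)nc32)c1`, is the next compound to be measured. It differs from compound 3 by chloro in place of hydrogen on an aromatic carbon. Among the measured compounds shown here, no step between two measured compounds is available to guide the size of this change, so the expectation rests on compound 3 alone. A small step toward lower tolerance is expected, a 1.7-fold lower number from compound 3 to compound 4 (0.24 log units; within the scatter), but one that may not exceed the usual scatter. Compound 4 is therefore estimated at 50000 nM, in a range from 15000 nM to 150000 nM.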

Compound 4, concentration lethal to 50% of the cells: > 100000 nM
Compound 4: only a limit was reported; the forecaster's own chance of this, stated with the estimate: 35%; middle value at least 2.0-fold (0.30 log units) from the limit.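

In this assay compound 4 gives > 100000 nM, which is a limit of the assay and not a number. Chloro in place of hydrogen, on the aromatic carbon between two ring nitrogen atoms, now has its first measured step, an at least 1.1-fold higher number from compound 3 to compound 4 (0.05 log units; that floor lies within the scatter), but this is only a floor, so the true size of the step remains unknown. The step gives no sign that chloro at this position lowers the number, although the ceiling of the assay hides how far it might go the other way: the limit of > 100000 nM in this assay, at which 2 of the 4 values shown sit.

The compounds shown leave open how an amine or a methoxy group at this same position would read. They also leave open whether any replacement here could bring the number clearly down into the range where the assay gives a real value.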